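The compounds below may be only part of what the source reports. "The series", "measured", "known", "first", "only" and "open" are said of these compounds alone.

Cytotoxicity in an ADME assay on NIH3T3 cells (Mus musculus) for cytotoxicity, read by MTT assay, with a stated time of 24 h (on this read-out higher numbers stand for weaker inhibition and lower numbers for stronger inhibition), is followed across a small set of analogues. Compound 2 `Cc1cc(-c2nc3ccccc3o2)ccc1NC(=O)CN1CCN(CCN(C)C)CC1` gives 63500 nM in this assay. Compound 1 `Cc1cc(-c2nc3cc(Cl)ccc3o2)ccc1NC(=O)CN1CCN(CCN(C)C)CC1` carries chloro in place of hydrogen on an aromatic carbon and in this assay gives 19200 nM, so the step is a 3.3-fold lower number from compound 2 to compound 1 (0.52 log units; beyond the scatter). Compound 3 `CN(C)CCCN1CCN(CC(=O)Nc2ccc(-c3nc4ccccc4o3)cc2)CC1` rests on a different core; the difference between the two cores is not broken down here. In this assay compound 3 gives 16700 nM. Compound 4 `CN(C)CCCN1CCN(CC(=O)Nc2ccc(-c3nc4cc(Cl)ccc4o3)cc2)CC1` is not yet measured; it differs from compound 3 by chloro in place of hydrogen on an aromatic carbon, which is the same change as that from compound 2 to compound 1. Given that the earlier step was a 3.3-fold lower number from compound 2 to compound 1 (0.52 log units; beyond the scatter), a step of similar size is expected here, a 2.8-fold lower number from compound 3 to compound 4 (0.44 log units; beyond the scatter), resting on that single measured pair. Compound 4 is therefore estimated at 6000 nM, most likely between 2500 nM and 15000 nM.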

Compound 4, half-maximal inhibitory concentration: 25800 nM
Estimate against measurement, compound 4: 4.3-fold (0.63 log units) below; measured number outside the range, above it.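

On the core of compound 3, chloro in place of hydrogen on an aromatic carbon gives a 1.5-fold higher number from compound 3 to compound 4 (0.19 log units; within the scatter) in this assay, and this does not match the step on the core of compound 2: the same change on two cores in this assay, a 3.3-fold lower number (0.52 log units; beyond the scatter) from compound 2 to compound 1 and a 1.5-fold higher number (0.19 log units; within the scatter) from compound 3 to compound 4, 5.1-fold (0.71 log units) apart, beyond the scatter of two such steps The lower number seen on the first core therefore cannot be carried to the second as a rule for this series. Among the compounds shown here, the result does not show which part of the difference between the cores separates the two steps, and it rests on only two pairs.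

Going by these compounds, it remains open whether bromo or methoxy in place of chloro on the same aromatic carbon would follow either step. On these data alone, it also remains open how either group would behave on each core.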